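A few compounds are considered here, and "the series" means these few. Any claim that something is new, unique, unknown or untested is made for them only; others in the source may bear on it.

Measured in an ADME assay on MRC5 cells (Homo sapiens), read by MTT assay, with a stated time of 72 h; on this read-out lower numbers stand for stronger inhibition and higher numbers for weaker inhibition:
- compound 1 `O=c1[nH]cnc2c1c(-c1ccccc1)cn2[C@@H]1O[C@H](CO)[C@@H](O)[C@H]1O`: > 100000 nM
- compound 2 `C#Cc1cn([C@@H]2O[C@H](CO)[C@@H](O)[C@H]2O)c2nc(C)nc(N)c12`: > 100000 nM
- compound 3 `Nc1nc2c(c(-c3ccco3)cn2[C@@H]2O[C@H](CO)[C@@H](O)[C@H]2O)c(=O)[nH]1`: > 100000 nM

All three entries are limits of the assay and not numbers, and they coincide: the limit of > 100000 nM in this assay, at which 3 of the 3 values shown sit. Compound 3 therefore has no numeric position in the series. Its entry of > 100000 nM is a limit.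

The next step keeps the shared core and the sugar unchanged and puts furan-3-yl in place of furan-2-yl on an aromatic carbon, (furan-3-yl in place of furan-2-yl on an aromatic carbon). The product is compound 4 `Nc1nc2c(c(-c3ccoc3)cn2[C@@H]2O[C@H](CO)[C@@H](O)[C@H]2O)c(=O)[nH]1`, which has the same atoms as compound 3, joined differently. For the measured compounds named here, no pair of measured compounds differing in one place is available to size such a change.

No shift beyond the scatter is expected in this assay, and a further limit is the likeliest result. The expected step of a number no higher from compound 3 to compound 4 (the limit leaves the size open) is an estimate resting on a limit alone. The estimate for compound 4 is 100000 nM, with an expected range of 30000 nM to 200000 nM.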

Compound 4, half-maximal inhibitory concentration: 86100 nM
For compound 4 the middle estimate is 1.2-fold (0.06 log units) above the measured one; measured number inside the range.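

In this assay compound 4, carrying furan-3-yl on the aromatic carbon, gives 86100 nM, the only numeric entry among the compounds shown, so this position can carry a group that yields a number in this assay. Compound 3, carrying furan-2-yl, gives > 100000 nM, which is a limit and not a number. The exchange of the two furan groups reads as an at least 1.1-fold lower number from compound 3 to compound 4 (0.06 log units; that floor lies within the scatter), a floor only, with the true size of the step left open: the limit of > 100000 nM in this assay, at which 3 of the 4 values shown sit.

As far as these compounds go, whether the two furan groups truly differ in this assay remains open, as does whether any other group on this aromatic carbon, such as thiophen-3-yl, an amine or a carboxylic acid, would give a lower number. From the compounds shown here alone, how furan-3-yl behaves on the core of compound 2 is also open.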